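The source may report more compounds than this note shows. Statements on the series, on what has been measured and on what is new or still open speak of the compounds shown alone.

Working notes on the series

Three esters of a shared core have been measured in a physicochemical assay for metabolic stability, read by LC-MS, in simulated gastric fluid, with a stated time of 15 min, tested at 50 uM; a lower number here means that less of the compound is left, a higher number that more of the compound is left. Compound 1 `O=C(OCc1ccccc1)c1coc(-c2ccccc2)n1` gives 1.8% in this assay. Compound 3 `CCc1ccccc1OC(=O)c1coc(-c2ccccc2)n1` gives 2.1%, and compound 2 `CCCc1ccccc1OC(=O)c1coc(-c2ccccc2)n1` gives 0.9%. The step of a number 1.2 percentage points lower from compound 3 to compound 2 (within the scatter) carries the change (methyl in place of hydrogen on a saturated chain carbon, two bonds along the chain from an aromatic carbon). All three numbers sit close together, and none of the gaps between them is outside the scatter, so no order among compounds 1, 2 and 3 can be read from this assay. The difference between the core of compound 1 and the core of compound 3 is not broken down here.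

Compound 4 `C[C@H](OC(=O)c1coc(-c2ccccc2)n1)c1ccccc1` has not yet been measured in this assay. It differs from compound 1 by methyl in place of hydrogen on a saturated chain carbon bound to an aromatic carbon and an oxygen next to a carbonyl group. For the measured compounds named here, this is the same kind of change as the one from compound 3 to compound 2, a methyl in place of hydrogen, but the surroundings differ: in compound 2 the saturated chain carbon lies two bonds along the chain from an aromatic carbon, whereas in compound 4 the saturated chain carbon is bound to an aromatic carbon and an oxygen next to a carbonyl group.

Because the measured step of a number 1.2 percentage points lower from compound 3 to compound 2 (within the scatter) stayed within the scatter, only a small step is expected from compound 1 to compound 4 as well, estimated at a number 0.3 percentage points lower from compound 1 to compound 4 (within the scatter). Compound 4 is therefore expected to give about 1.5% in this assay, with an estimated range from 0.3% to 4%, given that compound 1 gives 1.8% and every measured member of the series lies in the same low region.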

Compound 4, percent of the compound remaining: 5%
For compound 4 the middle estimate is 3.5 percentage points below the measured one; the whole stated range lies below it.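

In this assay the new step, a number 3.2 percentage points higher from compound 1 to compound 4 (within the scatter), lies within the scatter, as does the earlier step, a number 1.2 percentage points lower from compound 3 to compound 2 (within the scatter), and on the two cores shown methyl in place of hydrogen therefore gives no readable difference, whether it sits on a saturated chain carbon bound to an aromatic carbon and an oxygen next to a carbonyl group or two bonds along the chain from an aromatic carbon. This is agreement between two small steps only: it does not give the change a direction on either core, and with just these two pairs and all four numbers in a low region, it does not show that the change would stay as small on a core of which more is left in this assay at the end of the test. No measurement at hand bears on the reason for either step.

The compounds shown leave open whether anything larger than methyl on the saturated chain carbon of compound 4, such as a longer chain, would give a step beyond the scatter. They also leave open what an amine or a carboxylic acid in that place would give, and whether the mirror-image form of compound 4 would read the same.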